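Hydroxy for trifluoromethyl on two related triterpenoid scaffolds

The source may report more compounds than this note shows. Statements on the series, on what has been measured and on what is new or still open speak of the compounds shown alone.

Measured compounds:
compound 1, `CC(C)=CCC/C(C)=C/CC/C(C)=C/CC[C@@H]1[C@@]2(C)CC/C(=N\OCc3cn(-c4cccc(C(F)(F)F)c4)nn3)C(C)(C)[C@@H]2CC[C@@]1(C)O`, gives 22700 nM
compound 2, `CC(C)=CCC/C(C)=C/CC/C(C)=C/CC[C@@H]1[C@@]2(C)CC/C(=N\OCc3cn(-c4cccc(O)c4)nn3)C(C)(C)[C@@H]2CC[C@@]1(C)O`, gives 21200 nM
compound 3, `CC(C)=CCC/C(C)=C/CC/C(C)=C/CC[C@@H]1[C@@]2(C)C/C(=C\c3ccc(OCc4cn(-c5cccc(C(F)(F)F)c5)nn4)cc3)C(=O)C(C)(C)[C@@H]2CC[C@@]1(C)O`, gives 27600 nM

All three were tested in a functional assay on HepG2 cells (Homo sapiens) for cytotoxicity, read by MTT assay, with a stated time of 48 h; a lower number here means a stronger inhibitor, a higher number a weaker inhibitor. Compound 1 and compound 2 share one core and differ only in one group: hydroxy in place of trifluoromethyl on an aromatic carbon. The step this made, a 1.1-fold lower number from compound 1 to compound 2 (0.03 log units; within the scatter), is small, so the two values sit within the usual scatter and no order between them can be read. Compound 3 is built on a different core; the difference between the two cores is not broken down here. Its value lies within the scatter of both compound 1 and compound 2.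

Compound 4, `CC(C)=CCC/C(C)=C/CC/C(C)=C/CC[C@@H]1[C@@]2(C)C/C(=C\c3ccc(OCc4cn(-c5cccc(O)c5)nn4)cc3)C(=O)C(C)(C)[C@@H]2CC[C@@]1(C)O`, is not yet measured. It relates to compound 3 as compound 2 relates to compound 1: hydroxy in place of trifluoromethyl on an aromatic carbon. The place is described in the same words in both pairs, so this is the same change. The expectation for compound 4 rests on the step of a 1.1-fold lower number from compound 1 to compound 2 (0.03 log units; within the scatter), which was within the scatter. A step of similar size, a 1.1-fold lower number from compound 3 to compound 4 (0.03 log units; within the scatter), is therefore expected. Compound 4 is estimated at 26000 nM, with a range from 14000 nM to 50000 nM expected.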

Compound 4, half-maximal inhibitory concentration: 26900 nM
Estimate against measurement, compound 4: 1.0-fold (0.01 log units) below; the range from low to high includes it.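

In this assay, hydroxy in place of trifluoromethyl on the core of compound 3 gives a 1.0-fold lower number from compound 3 to compound 4 (0.01 log units; within the scatter), so no order can be read between these two compounds. Set beside the same change on the core of compound 1, the step shows no difference that can be told apart between the two cores: the same change on two cores in this assay, a 1.1-fold lower number (0.03 log units; within the scatter) from compound 1 to compound 2 and a 1.0-fold lower number (0.01 log units; within the scatter) from compound 3 to compound 4, 1.0-fold (0.02 log units) apart, within the scatter of two such steps This shows that the change left the number within the scatter on both cores, but it does not show that a real effect would carry from one core to the other, since neither step is large enough to test that, and two cores say nothing about any further core.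

The compounds shown carry only trifluoromethyl or hydroxy at this place on the aromatic ring, so it stays open whether an amine, a carboxylic acid or a methoxy group there would give a step beyond the scatter. Going by these compounds, it also stays open whether any such step would be the same on both cores.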